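Phenoxy for a halogenated phenyl in a growth hormone secretagogue agonist

A few compounds are considered here, and "the series" means these few. Any claim that something is new, unique, unknown or untested is made for them only; others in the source may bear on it.

Compound 1 `CC(=O)c1ccc(N2C[C@@H](C)N[C@@H](C)C2)cc1NS(=O)(=O)c1ccc(-c2ccccn2)s1` and compound 2 `COc1ccc(N2C[C@@H](C)N[C@@H](C)C2)cc1NS(=O)(=O)c1ccc(-c2cc(Cl)ccc2F)cc1` share a core and differ in the group at the end of the sulfonamide. In a functional assay for agonist activity at growth hormone secretagogue receptor type 1 (Homo sapiens), read by FLIPR (on this read-out higher numbers stand for larger maximal responses and lower numbers for smaller maximal responses), compound 1 gives 0.9, and compound 2 gives 1; these two values lie within the usual scatter of each other, so neither can be placed above the other. Compound 3 `COc1ccc(N2C[C@@H](C)N[C@@H](C)C2)cc1NS(=O)(=O)c1ccc(Oc2ccccc2)cc1` has not been measured; it differs from compound 2 in one place (phenoxy in place of 5-chloro-2-fluorophenyl on an aromatic carbon). With both known compounds giving near-full responses, the step from compound 2 to compound 3 is expected to stay within the scatter, at a number 0.10 lower from compound 2 to compound 3 (within the scatter). Compound 3 is estimated to give 0.9, between 0.7 and 1.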

Compound 3, intrinsic activity: the largest response reached, as a fraction of the reference agonist's: 0.9
Compound 3: middle estimate and measured number agree at the digits printed; the range from low to high includes it.
By their numbers in this assay, from the lowest: compounds 1, 3 and 2 (each within the scatter of the next).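

Swapping 5-chloro-2-fluorophenyl for phenoxy at this place, on an aromatic carbon para to a large group, gives a number 0.10 lower from compound 2 to compound 3 (within the scatter) in this assay. A near-full response therefore does not depend on the chlorine or the fluorine when an oxygen joins the ring to the core. No evidence at hand explains this result. From the compounds shown here alone, the halogens and the oxygen changed together, so their separate contributions remain unknown. Going by these compounds, it also remains open whether a plain phenyl, a benzyloxy group, an amine or a carboxylic acid at this place would keep the response.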